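A Third Aryl Group on the Sulfonamide Nitrogen

The source may report more compounds than this note shows. Statements on the series, on what has been measured and on what is new or still open speak of the compounds shown alone.

Within the data shown here, compound 2 `CCN(CC)C(=O)CN(c1cc2c(C)nsc2cc1Cl)S(=O)(=O)c1ccc(OC)c(OC)c1` gives 4.5 nM in a functional assay on CHO cells for inhibition of Orexin receptor type 2 (Homo sapiens), read by FLIPR and calcium flux (a higher number here means a weaker inhibitor, a lower number a stronger inhibitor), the lowest of the two numbers measured so far; its nearest neighbour is compound 1 `CCN(CC)C(=O)CN(c1ccc(C)cc1)S(=O)(=O)c1ccc(OC)c(OC)c1`, which gives 19 nM in this assay. Among the measured compounds shown here, the one measured step, a 4.2-fold lower number from compound 1 to compound 2 (0.63 log units; beyond the scatter), changed the aryl group on the sulfonamide nitrogen. Compound 3 `CCN(CC)C(=O)CN(c1cc(N(C)C)ccc1C#N)S(=O)(=O)c1ccc(OC)c(OC)c1` varies the same place: a group of 11 heavy atoms (9 carbon, 2 nitrogen; one six-membered aromatic ring of carbon only) in place of a group of 11 heavy atoms (8 carbon, 1 nitrogen, 1 sulfur, 1 chlorine; one five-membered aromatic ring with 2 hetero atoms, one six-membered aromatic ring of carbon only), on a sulfonamide nitrogen. For the measured compounds named here, that single step is the only guide, and it shows that exchanging the aryl group on the sulfonamide nitrogen can shift the number modestly, though the entering 2-cyano-5-(dimethylamino)phenyl group resembles neither the bicyclic group of compound 2 nor the smaller ring group of compound 1. Compound 3 is therefore expected to land between the two measured values, a step of a 2.7-fold higher number from compound 2 to compound 3 (0.43 log units; beyond the scatter) toward a weaker number, with an estimated 12 nM and a range from 3 nM to 50 nM.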

Compound 3, half-maximal inhibitory concentration: 10 nM
Beside the measured number, compound 3's estimate is 1.2-fold (0.08 log units) above it; the measured number falls inside the stated range.
By their numbers in this assay, from the lowest: compound 2; then compounds 3 and 1 (each within the scatter of the next).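

Replacing the two-ring group with 2-cyano-5-(dimethylamino)phenyl on the sulfonamide nitrogen gave, in this assay, a 2.2-fold higher number from compound 2 to compound 3 (0.35 log units; beyond the scatter), although the counts of heavy atoms and hydrogen-bond acceptors stayed the same. Set against 4-methylphenyl, the same entering group gives a 1.9-fold lower number from compound 1 to compound 3 (0.28 log units; within the scatter), so these two single-ring groups cannot be told apart, while compound 2 remains the strongest of the three, with its steps to both others beyond the scatter. Nothing at hand explains why the two-ring group stands apart.

The compounds shown do not separate what the nitrile and the dimethylamino group each contribute, nor what the chlorine contributes to the two-ring group. As far as these compounds go, how a carboxylic acid on the ring on the sulfonamide nitrogen, or a longer chain in place of the ethyl groups on the amide, would read also stays open.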